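The source may hold more compounds than are shown below. What is called first, only, known or untested is meant among the compounds shown, and "the series" means these compounds.

Measured compounds:
Compound 1 `Cc1nc(-c2cccc(C(F)(F)F)c2)sc1C(=O)N[C@H]1CN(S(=O)(=O)c2ccccc2)C[C@@H]1C(=O)N[C@H]1CCCNC1`: in an ADME assay on cells (Hepatocyte, Rattus norvegicus) for metabolic stability (on this read-out lower numbers stand for slow clearance and higher numbers for fast clearance), compound 1 gives 2.9 uL/min.
Compound 2 `O=C(N[C@H]1CN(S(=O)(=O)c2ccccc2)C[C@@H]1C(=O)N[C@H]1CCCNC1)c1cc(-c2ccccc2Cl)on1`: in this assay compound 2 gives 8.3 uL/min.
Compound 3 `O=C(N[C@H]1CN(S(=O)(=O)c2ccccc2)C[C@@H]1C(=O)N1C[C@H]2CCNC[C@H]21)c1cc(-c2ccccc2Cl)on1`: in this assay compound 3 gives 4.7 uL/min.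

Compound 3 holds the second highest of the three numbers. Its nearest neighbour is compound 1, whose number is lower, and the furthest is compound 2, whose number is higher; both gaps lie within the scatter, so the three compounds are not separated by these data.

Compound 4 `O=C(N[C@H]1CN(S(=O)(=O)c2ccccc2)C[C@@H]1C(=O)NC[C@@H]1CCCN1)c1cc(-c2ccccc2Cl)on1` arises from compound 3 by the change (a group of 7 heavy atoms (5 carbon, 2 nitrogen; one five-membered non-aromatic ring with 1 hetero atom) in place of a group of 8 heavy atoms (6 carbon, 2 nitrogen; one four-membered non-aromatic ring with 1 hetero atom, one six-membered non-aromatic ring with 1 hetero atom), on a carbonyl carbon). Within the data shown here, the one measured step that bears on it is the change at the same carbonyl carbon, a 1.8-fold lower number from compound 2 to compound 3 (0.25 log units; within the scatter), which stayed within the scatter. Since the amine attached to that carbonyl carbon has moved once without an effect beyond the scatter, the return to a ((pyrrolidin-2-yl)methyl)amino group is expected to behave alike, with a step of a 1.3-fold higher number from compound 3 to compound 4 (0.11 log units; within the scatter) that is expected to be within the scatter. Compound 4 is therefore estimated at 6 uL/min, with a range from 3 uL/min to 13 uL/min.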

Compound 4, intrinsic clearance in a liver preparation (reported as CLH), per the amount of preparation that the assay uses: 22 uL/min
For compound 4 the middle estimate is 3.7-fold (0.56 log units) below the measured one, outside the stated range (above it).
By their numbers in this assay, from the lowest: compounds 1, 3 and 2 (each within the scatter of the next, the first and the last beyond it); then compound 4.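

In this assay the amine on this carbonyl carbon turns out to matter: the ((pyrrolidin-2-yl)methyl)amino group gives a 4.7-fold higher number from compound 3 to compound 4 (0.67 log units; beyond the scatter) and also a 2.7-fold higher number from compound 2 to compound 4 (0.42 log units; beyond the scatter), both beyond the scatter, whereas a 1.8-fold lower number from compound 2 to compound 3 (0.25 log units; within the scatter) had stayed within it. Compound 4 therefore stands apart from both other amides of this acid, and the position is shown to respond to the choice of amine, though only modestly. Nothing at hand accounts for this rise in the number.

Compound 4 differs from compound 2 in both ring size and the chain to the amide-type nitrogen, so the two changes cannot be told apart here. On these data alone, a pyrrolidin-3-yl or a (piperidin-3-yl)methyl group on that nitrogen would separate them, and whether the same step holds with the acyl group of compound 1 stays open.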